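The source may report more compounds than this note shows. Statements on the series, on what has been measured and on what is new or still open speak of the compounds shown alone.

For the measured compounds named here, in a functional assay on Right cardiac atrium for agonist activity at histamine H2 receptor (Cavia porcellus), with a stated time of 30 min, in the presence of a further agent that is not named here (a higher number here means that more compound is needed for the effect, a lower number that less compound is needed), compound 2 `Cc1ccc(C(C)NC(=O)/N=C(\N)NCCCc2sc(N)nc2C)cc1` gives 22.4 nM, which is the lowest of the two numbers measured so far. Going by the values given here, its nearest neighbour is compound 1 `Cc1nc(N)sc1CCCN/C(N)=N/C(=O)NC(C)c1ccc(OC(F)(F)F)cc1`, which in this assay gives 724 nM; the only measured step, a 32-fold lower number from compound 1 to compound 2 (1.51 log units; beyond the scatter), arose from swapping one small group on the aromatic ring. Compound 3 `Cc1nc(N)sc1CCCN/C(N)=N/C(=O)NC(C)c1ccco1` is not yet measured and differs from compound 2 in another way: furan-2-yl in place of 4-methylphenyl on a saturated chain carbon bound to an amide-type nitrogen and a saturated chain carbon. Among the compounds with values here, no measured step touches a change of the ring itself, so the single known step offers only a loose guide, and the direction of the change cannot be read from the data. Compound 3 is therefore expected to need somewhat more compound than compound 2, a step of about a 3.1-fold higher number from compound 2 to compound 3 (0.49 log units; beyond the scatter), with wide uncertainty. The estimate for compound 3 in this assay is 70 nM, within a range from 15 nM to 400 nM.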

Compound 3, half-maximal effective concentration: 9.77 nM
Compound 3: middle estimate off by 7.2-fold (0.86 log units), on the high side; the whole stated range lies above it.
By their numbers in this assay, from the lowest: compound 3; then compound 2; then compound 1.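

In this assay, the group on the saturated chain carbon bound to an amide-type nitrogen and a saturated chain carbon can be replaced as a whole ring, and furan-2-yl in place of 4-methylphenyl gives a 2.3-fold lower number from compound 2 to compound 3 (0.36 log units; beyond the scatter). The earlier step, a 32-fold lower number from compound 1 to compound 2 (1.51 log units; beyond the scatter), changed only a substituent on the ring, whereas this one shows that a six-membered aromatic ring of carbon only is not required here: a five-membered aromatic ring with 1 hetero atom, fewer heavy atoms and 1 hydrogen-bond acceptor needs less compound for the effect. No measurement offered here explains this shift.

Ring size and the ring oxygen change together in this step, so their separate contributions remain open. A thiophen-2-yl ring would keep the five-membered ring while replacing the oxygen with sulfur, and a cyclohexyl group would test whether an aromatic ring is needed at all.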